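The source may hold more compounds than are shown below. What is called first, only, known or untested is meant among the compounds shown, and "the series" means these compounds.

Working notes on the series, read in a functional assay on RAW264.7 cells (Mus musculus) for inhibition, read by Griess assay, with stated times of 2 h and 18 h; a higher number here means a weaker inhibitor, a lower number a stronger inhibitor. Compound 1 `CC1=C(CCc2ccoc2)[C@@]2(C)CCC(=O)C(C)(C)C2=C(O)C1=O` gives > 50000 nM, which is a limit. Among the compounds with values here, compound 2 `CCOC1CC(O)(CCC2=C(C)C(=O)C(O)=C3C(C)(C)C(=O)CC[C@]23C)CO1` gives 22900 nM, the only true number so far. Compound 3 `CO[C@H]1C=C(CCC2=C(C)C(=O)C(O)=C3C(C)(C)C(=O)CC[C@]23C)C(=O)O1` gives > 50000 nM, which is also a limit and not a number. The series therefore shows (the limit of > 50000 nM in this assay, at which 2 of the 3 values shown sit).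

Compound 4 `CO[C@@H]1C=C(CCC2=C(C)C(=O)C(O)=C3C(C)(C)C(=O)CC[C@]23C)C(=O)O1` is the next entry: the two compounds have the same atoms and bonds and differ only in configuration as drawn: 1 of 2 stereo elements differ; a stereocentre at a saturated ring carbon is drawn R in compound 3 and S in compound 4.

Within the data shown here, two measured steps bear on it only indirectly: an at least 2.1-fold lower number from compound 1 to compound 2 (0.33 log units; beyond the scatter), and an at least 2.1-fold higher number from compound 2 to compound 3 (0.33 log units; beyond the scatter). Both exchange the group on the chain, and both are beyond the scatter, but neither changes configuration alone. Among the measured compounds shown here, no measured pair isolates the stereocentre, so its effect is unknown. No step beyond the scatter is expected in this assay, and no direction is favoured. The expected change is a number no higher from compound 3 to compound 4 (the limit leaves the size open). Compound 4 is estimated at 50000 nM, within an expected range of 22000 nM to 110000 nM.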

Compound 4, half-maximal inhibitory concentration: > 50000 nM
Compound 4 gave a limit, no number (the forecaster's own chance of this, stated with the estimate: 65%); the middle value lies on the limit itself.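

In this assay, compound 4 sits at the same limit as compound 3, so neither drawn configuration of the stereocentre at the saturated ring carbon gives a true number: the limit of > 50000 nM in this assay, at which 3 of the 4 values shown sit. The steps from compound 3 to compound 4 and from compound 1 to compound 4 cannot be read, so this pair gives neither a size nor a direction for the change, although its single difference is clear: the fact that compounds 3 and 4 differ only in the configuration as drawn. Exchanging the group on the chain gives an at least 2.1-fold higher number from compound 2 to compound 4 (0.33 log units; beyond the scatter), so the gap already seen with the R form also holds with the S form.

From the compounds shown here alone, whether the stereocentre affects inhibition at all remains open while both forms stay at the limit. Also open, going by these compounds, is how a chain ending in an amine or a carboxylic acid, in place of these rings, would read in this assay.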